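Swapping Iodine for Bromine on a Calpain Inhibitor

A few compounds are considered here, and "the series" means these few. Any claim that something is new, unique, unknown or untested is made for them only; others in the source may bear on it.

Compound 1 `O=C(O)/C(S)=C/c1c[nH]c2ccc(I)cc12` and compound 2 `O=C(O)/C(S)=C/c1c[nH]c2ccc(Br)cc12` share a core and differ by bromo in place of iodo on an aromatic carbon. In an assay on isolated protein for inhibition of Calpain-1 catalytic subunit (Sus scrofa) (a lower number here means a stronger inhibitor, a higher number a weaker inhibitor), compound 1 gives 90 nM, and compound 2 gives 20 nM; the step is a 4.5-fold lower number from compound 1 to compound 2 (0.65 log units; beyond the scatter). Compound 3 `O=C(O)/C(S)=C/c1c[nH]c2c(I)cccc12` has the same atoms as compound 1, joined differently; how the two cores differ is not broken down here. In this assay compound 3 gives 220 nM, the highest number of the three. Compound 4 `O=C(O)/C(S)=C/c1c[nH]c2c(Br)cccc12` differs from compound 3 by bromo in place of iodo on an aromatic carbon. This is the same kind of change as from compound 1 to compound 2, but at a different place: there the halogen is meta to a fused ring and para to a fused ring, here ortho to a fused ring and meta to a fused ring. For compound 4 a step of a 2.8-fold lower number from compound 3 to compound 4 (0.44 log units; beyond the scatter) is expected. A somewhat smaller step than before is expected because a 4.5-fold lower number from compound 1 to compound 2 (0.65 log units; beyond the scatter) was seen at a different place on the ring and rests on one pair only. Compound 4 is therefore estimated at 80 nM, likely between 30 nM and 220 nM.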

Compound 4, half-maximal inhibitory concentration: 70 nM
Compound 4: middle estimate off by 1.1-fold (0.06 log units), on the high side, and the stated range covers the measured number.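

In this assay bromo in place of iodo gives a 3.1-fold lower number from compound 3 to compound 4 (0.50 log units; beyond the scatter) on this second core as well. The two steps point the same way and match in size within the scatter: the same change on two cores in this assay, a 4.5-fold lower number (0.65 log units; beyond the scatter) from compound 1 to compound 2 and a 3.1-fold lower number (0.50 log units; beyond the scatter) from compound 3 to compound 4, 1.4-fold (0.16 log units) apart, within the scatter of two such steps. Among these compounds, this shows that the change carried over between these two cores in this assay, but it rests on only two pairs, and it does not show that the same would hold on any other core or in any other assay, or why bromo gives the lower number.

The compounds shown leave open how a lighter halogen such as chloro or fluoro would compare with bromo at either place on the ring. They also leave open what a non-halogen group, such as methoxy or a nitrile, would do there.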